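Changing the aryl group on the aromatic nitrogen

A few compounds are considered here, and "the series" means these few. Any claim that something is new, unique, unknown or untested is made for them only; others in the source may bear on it.

This account concerns two measured compounds and one that has not yet been tested in an ADME assay on HUVEC cells (Homo sapiens) for antiproliferative activity, read by MTT assay, with a stated time of 48 h; on this read-out lower numbers stand for stronger inhibition and higher numbers for weaker inhibition. Compound 1 `COc1ccc(-n2nncc2CN2C(=O)C3(C(C#N)=C(N)Oc4c3c3nc5ccccc5nc3c3ccccc43)c3ccccc32)cc1` reaches only the limit of > 50000 nM in this assay, so no number is available for it. Compound 2 `N#CC1=C(N)Oc2c(N)cc3nc4ccccc4nc3c2C12C(=O)N(Cc1cnnn1-c1ccccc1Br)c1ccccc12` gives 34200 nM in this assay, and this is the only number shown for the pair. One of the two values is a limit rather than a number (the limit of > 50000 nM in this assay, at which 1 of the 2 values shown sits). Compound 3 `CCc1cccc(C)c1-n1nncc1CN1C(=O)C2(C(C#N)=C(N)Oc3c(N)cc4nc5ccccc5nc4c32)c2ccccc21` differs from compound 2 in a single place: 2-ethyl-6-methylphenyl in place of 2-bromophenyl on an aromatic nitrogen. Among the compounds with values here, no step between measured compounds is available here, so the data give no measured size for such a change. The step of a 1.2-fold higher number from compound 2 to compound 3 (0.07 log units; within the scatter) is expected to be small, within the usual scatter or a little toward weaker inhibition. Compound 3 is therefore estimated at 40000 nM in this assay, with a range from 15000 nM to 100000 nM, and a reading that ends at the limit rather than as a number is a real possibility.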

Compound 3, half-maximal inhibitory concentration: > 50000 nM
Compound 3 gave a limit, no number; the forecaster's own chance of this, stated with the estimate: 40%; middle value at least 1.2-fold (0.09 log units) from the limit.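

Within the data shown here, this is the first measured change at this position, the aromatic nitrogen of the five-membered ring with 3 nitrogen, with the rest of the molecule held constant: putting 2-ethyl-6-methylphenyl in place of 2-bromophenyl gives an at least 1.4-fold higher number from compound 2 to compound 3 (0.16 log units; that floor lies within the scatter). The step is only a floor, since in this assay compound 3 reads > 50000 nM, which is a limit of the assay and not a number, so the true size of the change could lie within the scatter or well beyond it. What the result does show is that this carbon-only aryl group, with its ethyl and methyl substituents, brings no measurable gain over the bromine-bearing aryl group, and the series now offers very little room for reading differences: the limit of > 50000 nM in this assay, at which 2 of the 3 values shown sit.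

The compounds shown leave open how far compound 3 truly lies from compound 2, and whether any group at this position can give a number clearly lower than that of compound 2. An aryl group carrying an amine or a carboxylic acid, or a simple benzyl group on the same nitrogen, would test this in the same assay.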